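A few compounds are considered here, and "the series" means these few. Any claim that something is new, unique, unknown or untested is made for them only; others in the source may bear on it.

Measured in an ADME assay on microsomes from liver (Mus musculus) for metabolic stability, read by LC-MS, with a stated time of 10 min, tested at 0.5 uM; a lower number here means that less of the compound is left, a higher number that more of the compound is left:
compound 1 `c1ccc2c(c1)CN[C@@H](CN(CCCN1CCNCC1)[C@H]1CCCc3cccnc31)C2`: 92%
compound 2 `c1cnc2c(c1)CCC[C@@H]2N(CCCN1CCNCC1)Cc1cc2ccccc2cn1`: 74%
compound 3 `c1cnc2c(c1)CN[C@H](CN(CCCN1CCNCC1)[C@H]1CCCc3cccnc31)C2`: 63%

Compound 3 stands lowest of the three, with compound 2 nearest and compound 1 furthest. The next step leads to compound 4 `c1cnc2c(c1)CCC[C@@H]2N(CCCN1CCNCC1)Cc1nc2ccccc2[nH]1`, which differs from it as follows: a group of 9 heavy atoms (7 carbon, 2 nitrogen; one five-membered aromatic ring with 2 hetero atoms, one six-membered aromatic ring of carbon only) in place of a group of 10 heavy atoms (8 carbon, 2 nitrogen; one six-membered non-aromatic ring with 1 hetero atom, one six-membered aromatic ring with 1 hetero atom), on a saturated chain carbon bound to an amine nitrogen. The entering group is 1H-benzimidazol-2-yl.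

Among the measured compounds shown here, two measured steps bear on this change: a number 29 percentage points lower from compound 1 to compound 3 (beyond the scatter), and a number 11 percentage points lower from compound 2 to compound 3 (beyond the scatter). Both are modest and beyond the scatter. In each, a group with a six-membered aromatic ring of carbon only leaves, and the group that compound 4 gives up enters. The change to compound 4 brings such a ring back, so a rise is expected, roughly the reverse of the smaller step. Compound 2, at 74%, is taken as the closer guide: its group, like 1H-benzimidazol-2-yl, has no non-aromatic ring. For the measured compounds named here, no measured compound carries the five-membered aromatic ring with 2 hetero atoms, so the range stays wide.

The expected change is a number 12 percentage points higher from compound 3 to compound 4 (beyond the scatter), a modest upward step. For compound 4 the estimate is 75%, with an expected range of 58% to 90%.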

Compound 4, percent of the compound remaining: 68%
Compound 4: middle estimate off by 7 percentage points, on the high side; the range from low to high includes it.
By their numbers in this assay, from the lowest: compounds 3, 4 and 2 (each within the scatter of the next, the first and the last beyond it); then compound 1.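

In this assay, 1H-benzimidazol-2-yl on a saturated chain carbon bound to an amine nitrogen gives a number 5 percentage points higher from compound 3 to compound 4 (within the scatter) and a number 6 percentage points lower from compound 2 to compound 4 (within the scatter), so compound 4 cannot be told apart from either neighbour, even though compound 2 and compound 3 lie beyond the scatter of each other. Among the compounds shown here, the return of a six-membered aromatic ring of carbon only is thus not enough for a readable gain over compound 3, and compound 4 still shows a number 24 percentage points lower from compound 1 to compound 4 (beyond the scatter), leaving 1,2,3,4-tetrahydroisoquinolin-3-yl as the only group of the four beyond the scatter of all the others. No supporting data bear on the reason for these differences.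

Open, on these data alone, is whether the five-membered aromatic ring with 2 hetero atoms matters on its own, as a 1H-imidazol-2-yl or a plain phenyl at this place would show by separating it from the six-membered aromatic ring of carbon only. Also open, as far as these compounds go, is whether a methyl on the benzimidazole nitrogen, which would remove the ring's hydrogen-bond donor, moves the number at all.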